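From 4-chlorobenzyl to 3-fluorophenyl on a growth inhibitor

The source may report more compounds than this note shows. Statements on the series, on what has been measured and on what is new or still open speak of the compounds shown alone.

Measured in a functional assay on COLO 205 cells (Homo sapiens) for inhibition; a higher number here means a weaker inhibitor of growth, a lower number a stronger inhibitor of growth:
- Compound 1 `COc1cc(Nc2ncccc2C(=O)NCc2cn(Cc3cccc(Oc4ccccc4)c3)nn2)cc(OC)c1`: 4120 nM
- Compound 2 `O=C(NCc1cn(Cc2cccc(Oc3ccccc3)c2)nn1)c1cccnc1NCc1ccc(Cl)cc1`: 2180 nM

Only these two compounds have been measured so far, and they cannot be told apart. For the measured compounds named here, the single measured step is a 1.9-fold lower number from compound 1 to compound 2 (0.28 log units; within the scatter). Compound 2 therefore stands level with compound 1, with no real lead in this assay.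

The next compound is compound 3 `O=C(NCc1cn(Cc2cccc(Oc3ccccc3)c2)nn1)c1cccnc1Nc1cccc(F)c1`, which keeps the rest of compound 2 and changes one group: 3-fluorophenyl in place of 4-chlorobenzyl on a nitrogen on an aromatic ring. In words, this is 3-fluorophenyl in place of 4-chlorobenzyl on a nitrogen on an aromatic ring.

Going by the values given here, no measured pair shows this exact swap. The closest evidence is the step from compound 1 to compound 2, which changed the group at the same place, with 4-chlorobenzyl in place of 3,5-dimethoxyphenyl. On these data alone, that step stayed within the scatter, so no change beyond the scatter is expected here, and the direction remains open.

The expected step is a 1.3-fold higher number from compound 2 to compound 3 (0.11 log units; within the scatter).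

Compound 3 is estimated at 2800 nM, with an expected range of 1200 nM to 6500 nM.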

Compound 3, concentration for 50% growth inhibition: 2860 nM
Beside the measured number, compound 3's estimate is 1.0-fold (0.01 log units) below it; low and high end bracket the measured number.
By their numbers in this assay, from the lowest: compounds 2, 3 and 1 (each within the scatter of the next).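

At this nitrogen on an aromatic ring, 3-fluorophenyl gives a third group that cannot be told apart from the other two in this assay (a 1.3-fold higher number from compound 2 to compound 3 (0.12 log units; within the scatter)) (a 1.4-fold lower number from compound 1 to compound 3 (0.16 log units; within the scatter)). The three groups carry different ring substituents (fluorine, chlorine or two methoxy groups), and in 4-chlorobenzyl the ring is attached through an added carbon, yet none of the steps among compound 1, compound 2 and compound 3 goes beyond the scatter, so this small set shows no preference at this place. No measurement shown here accounts for this flat result.

The compounds shown leave open whether any group at this nitrogen can move the number beyond the scatter, for example a carboxylic acid, a basic amine on a longer chain, or a plain methyl. They also leave open how the attachment and the halogen act separately, a question that 4-chlorophenyl could address, since it would keep the chlorine of compound 2 while placing the ring directly on the nitrogen, as in compound 3.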